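Swapping a para chloro for methylsulfonyl on a FAAH inhibitor

The source may report more compounds than this note shows. Statements on the series, on what has been measured and on what is new or still open speak of the compounds shown alone.

Compound 1, `COC(=O)c1ccc(CCCCCCC(=O)c2ncc(-c3ccccn3)o2)cc1`, gives 1.5 nM in an assay for inhibition of Fatty-acid amide hydrolase 1 (Rattus norvegicus); on this read-out lower numbers stand for stronger inhibition and higher numbers for weaker inhibition.
Compound 2, `O=C(O)c1ccc(CCCCCCC(=O)c2ncc(-c3ccccn3)o2)cc1`, gives only a limit of this assay, > 600 nM.
Compound 3, `O=C(CCCCCCc1ccc(Cl)cc1)c1ncc(-c2ccccn2)o1`, gives 2.7 nM.

Three compounds share one core and differ only in the group on the aromatic ring at the end of the chain. Compound 3 carries the higher of the two real numbers, yet the step of a 1.8-fold higher number from compound 1 to compound 3 (0.26 log units; within the scatter) is within the scatter, so compound 1 and compound 3 cannot be told apart. Compound 2 stands apart: the step of an at least 220-fold lower number from compound 2 to compound 3 (2.34 log units; beyond the scatter) is large, and the limit of > 600 nM in this assay, at which 1 of the 3 values shown sits, marks where its value sits.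

Compound 4, `CS(=O)(=O)c1ccc(CCCCCCC(=O)c2ncc(-c3ccccn3)o2)cc1`, is the next candidate. It differs from compound 3 by methylsulfonyl in place of chloro on an aromatic carbon. The step of a 1.8-fold higher number from compound 1 to compound 3 (0.26 log units; within the scatter) shows that replacing chloro with methoxycarbonyl, a group without net charge, changes nothing beyond the scatter, whereas the step of an at least 220-fold lower number from compound 2 to compound 3 (2.34 log units; beyond the scatter) shows carboxy costing a great deal. Methylsulfonyl, like methoxycarbonyl, carries no net charge, so compound 4 is expected to stay close to compound 3, with an estimated step of a 1.5-fold higher number from compound 3 to compound 4 (0.17 log units; within the scatter). The estimate for compound 4 is therefore 4 nM, within a range from 1 nM to 25 nM.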

Compound 4, inhibition constant: 19 nM
The estimate for compound 4 lay 4.8-fold (0.68 log units) below the measured number; the measured number falls inside the stated range.
By their numbers in this assay, from the lowest: compounds 1 and 3 (each within the scatter of the next); then compound 4. At a limit, above all of these: compound 2.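

The position turns out not to treat all groups without net charge alike: chloro and methoxycarbonyl could not be told apart, yet methylsulfonyl brings a 7.0-fold higher number from compound 3 to compound 4 (0.85 log units; beyond the scatter) and a 13-fold higher number from compound 1 to compound 4 (1.10 log units; beyond the scatter). Compound 2 gives only a limit in this assay, and the step to the new compound is an at least 31-fold lower number from compound 2 to compound 4 (1.49 log units; beyond the scatter), so methylsulfonyl keeps far more inhibition than carboxy. Having no net charge is therefore not enough to keep the number close to that of compound 3, and methylsulfonyl sits in its own place between the two earlier extremes.

As far as these compounds go, whether an amine, a nitrile or a methoxy group here would stay with chloro or fall nearer methylsulfonyl remains open, as does whether a longer chain would change these steps. Nothing measured here tells why methylsulfonyl behaves differently from methoxycarbonyl.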